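The source may hold more compounds than are shown below. What is called first, only, known or untested is meant among the compounds shown, and "the series" means these compounds.

Among the measured compounds shown here, compound 1 `NC1=NN(c2ccccc2)C(=O)/C1=C/Nc1ccc(S(=O)(=O)Nc2ccccn2)cc1` is one of two compounds measured in a functional assay on HepG2 cells (Homo sapiens) for positive allosteric modulation, tested at 5 uM; a lower number here means a weaker effect, a higher number a stronger effect of the compound at the concentration tested. In this assay compound 1 gives 62.1%. Compound 2 `N=C1NN=C(N)/C1=C\Nc1ccc(S(=O)(=O)Nc2cnc3ccccc3n2)cc1`, which carries the quinoxalin-2-yl group on its sulfonamide nitrogen but has a different core, gives 53.6% in this assay. The two numbers lie within the scatter of each other, so compound 1 stands level with compound 2 rather than apart from it. Compound 3 `NC1=NN(c2ccccc2)C(=O)/C1=C/Nc1ccc(S(=O)(=O)Nc2cnc3ccccc3n2)cc1` has not yet been measured. It differs from compound 1 in one place: quinoxalin-2-yl in place of pyridin-2-yl on a sulfonamide nitrogen. For the measured compounds named here, the two measured compounds differ in more than one place, and no measured step matches this single change. The values of compound 1 and compound 2 show that compounds with either group on the sulfonamide nitrogen can give read-outs in a similar range. Compound 3 is therefore expected to give about 58%, within a range from 40% to 75%. The expected step of a number 4.1 percentage points lower from compound 1 to compound 3 (within the scatter) is small, in no particular direction, and not beyond the scatter.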

Compound 3, a percentage reported as activity, at one concentration (the size of the read-out at that concentration, not a potency): 57.1%
For compound 3 the middle estimate is 0.9 percentage points above the measured one, within the range that was stated.
By their numbers in this assay, from the lowest: compounds 2, 3 and 1 (each within the scatter of the next).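

In this assay the change to quinoxalin-2-yl in place of pyridin-2-yl on a sulfonamide nitrogen gives a number 5 percentage points lower from compound 1 to compound 3 (within the scatter) with the rest of the molecule unchanged. Among the compounds shown here, this is the first direct comparison of the two groups on the same core, and it shows that this position can carry the extra aromatic ring of quinoxalin-2-yl with no read-out that can be told apart from that of compound 1. No measurement at hand bears on why the two groups read alike.

As far as these compounds go, both groups are aromatic rings containing nitrogen, so it remains open whether a plain phenyl ring, a methyl group or an acetyl group on the same sulfonamide nitrogen would give a similar read-out. From the compounds shown here alone, each number gives the size of the effect at a single concentration, so whether these compounds would give a stronger or weaker effect at other concentrations also remains open.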